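From an Aryl Triazole to a Sulfonamide-Bearing Analogue

This account rests on a few compounds, and the source may have more. Where it says the series, first, only, none or still open, it means among the compounds named here.

Among the compounds with values here, compound 1 `O=C1O[C@H]([C@@H](O)Cn2cc(-c3ccc(Br)cc3)nn2)C(OCc2ccccc2)=C1OCc1ccccc1` holds the only number in the set: in a functional assay on A549 cells (Homo sapiens) for antiproliferative activity, read by MTT assay, with a stated time of 72 h (a lower number here means a stronger inhibitor, a higher number a weaker inhibitor), compound 1 gives 750 nM. The two other measured compounds sit at a limit of the assay rather than at a number. Compound 2 `O=C1O/C(=C\Cn2cc(-c3cc(F)cc(F)c3)nn2)C(OCc2ccccc2)=C1OCc1ccccc1` gives > 100000 nM in this assay, which is a limit. Compound 3 `COc1ccc(-c2cn(C/C=C3\OC(=O)C(OCc4ccccc4)=C3OCc3ccccc3)nn2)cc1` gives > 100000 nM in this assay, again a limit. Within the data shown here, the one step measured between compounds that differ in a single place, a step that the two limits leave unreadable from compound 2 to compound 3, cannot be read because of the limit of > 100000 nM in this assay, at which 2 of the 3 values shown sit. Among the measured compounds shown here, compounds 2 and 3 each differ from compound 1 in more than one place, so their values show only that compound 1 alone reaches a number.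

Compound 4 `O=C1O[C@H]([C@@H](O)Cn2cc(CNS(=O)(=O)c3ccc(Cl)cc3)nn2)C(OCc2ccccc2)=C1OCc1ccccc1` differs from compound 1 in one place: (((4-chlorophenyl)sulfonyl)amino)methyl in place of 4-bromophenyl on an aromatic carbon. For the measured compounds named here, no measured step touches the loss of the 4-bromophenyl or the entry of the sulfonamide-bearing group, so the measured steps give no direct guide. A moderate loss is expected, estimated as the step of a 3.3-fold higher number from compound 1 to compound 4 (0.52 log units; beyond the scatter). Compound 4 is therefore expected to give about 2500 nM in this assay, between 500 nM and 20000 nM.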

Compound 4, half-maximal inhibitory concentration: 2870 nM
Compound 4: the middle estimate sits 1.1-fold (0.06 log units) below what was measured; measured number inside the range.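

Within the data shown here, with a 3.8-fold higher number from compound 1 to compound 4 (0.58 log units; beyond the scatter) in this assay, the aromatic carbon of the five-membered ring with 3 nitrogen now carries a readable change, which the earlier compounds did not provide. The 4-bromophenyl is therefore not required for a measurable value: with (((4-chlorophenyl)sulfonyl)amino)methyl at this place, which brings a hydrogen-bond donor and hydrogen-bond acceptors that the 4-bromophenyl lacks, compound 4 still gives a number rather than a limit. Nothing shown here accounts for the size of this step.

Among these compounds, the single step changes the linking atoms, the sulfonyl group and the ring halogen at once, so what each contributes remains open. On these data alone, how an amine, a carboxylic acid or a longer chain in place of the methyl would behave at this position also remains open.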